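A few compounds are considered here, and "the series" means these few. Any claim that something is new, unique, unknown or untested is made for them only; others in the source may bear on it.

Among the three compounds measured so far, compound 3 `CC(C)(C)N(NC(=O)c1ccc(Br)cc1)C(=O)c1ccccc1Cl` stands at the lowest number. In an assay on cells for agonist activity at ecdysone receptor (Bombyx mori), read by a luciferase reporter, with a stated time of 24 h (on this read-out higher numbers stand for an effect only at larger amounts of compound and lower numbers for an effect already at smaller amounts), compound 3 gives 33.9 nM, while compound 2 `CC(C)(C)N(NC(=O)c1ccc(Cl)cc1)C(=O)c1ccccc1Cl` gives 115 nM and compound 1 `CC(C)(C)N(NC(=O)c1ccccc1Cl)C(=O)c1ccccc1Cl` gives 331 nM. The steps of a 2.9-fold lower number from compound 1 to compound 2 (0.46 log units; beyond the scatter) and a 9.8-fold lower number from compound 1 to compound 3 (0.99 log units; beyond the scatter) show that moving and swapping the halogen mattered, and the step of a 3.4-fold lower number from compound 2 to compound 3 (0.53 log units; beyond the scatter) shows that exchanging one halogen for another at the same place mattered too.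

Compound 4 `Cc1ccc(C(=O)NN(C(=O)c2ccccc2Cl)C(C)(C)C)cc1` is reached from compound 3 by a single change: methyl in place of bromo on an aromatic carbon. Among the measured compounds shown here, only the step of a 3.4-fold lower number from compound 2 to compound 3 (0.53 log units; beyond the scatter) bears directly on this, since it is the one exchange of the group at this very position, and it shifted the number by a modest amount. A methyl in place of bromo is expected to give a small shift in the other direction, possibly within the scatter. The expected step is a 1.9-fold higher number from compound 3 to compound 4 (0.28 log units; within the scatter). Compound 4 is therefore estimated at 65 nM, with a range from 18 nM to 240 nM.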

Compound 4, half-maximal effective concentration: 18.6 nM
Beside the measured number, compound 4's estimate is 3.5-fold (0.54 log units) above it; the range from low to high includes it.
By their numbers in this assay, from the lowest: compounds 4 and 3 (each within the scatter of the next); then compound 2; then compound 1.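

In this assay the step of a 1.8-fold lower number from compound 3 to compound 4 (0.26 log units; within the scatter) shows that bromo and methyl cannot be told apart at this position, so among the groups shown here, a halogen is not needed for a low number. Chloro at the same place gives a clearly different result, with a 6.2-fold lower number from compound 2 to compound 4 (0.79 log units; beyond the scatter) from this single exchange, so the two halogens shown do not behave alike and one carbon-based group matches the better of them. The 4-methylphenyl group also holds up against the 2-chlorophenyl group, with an 18-fold lower number from compound 1 to compound 4 (1.25 log units; beyond the scatter) in a step that counts as large.

Nothing at hand explains why these groups fall in this order. From the compounds shown here alone, whether a longer chain such as ethyl, a methoxy group, an amine or a carboxylic acid at this position would keep the number as low remains open.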